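The compounds below may be only part of what the source reports. "The series", "measured", "known", "first", "only" and "open" are said of these compounds alone.

Working notes on the series. Among the measured compounds shown here, compound 1 `C[C@@H](Cn1ccc(-c2ccc(C#N)c(Cl)c2)n1)NC(=O)c1ccccc1F` in a functional assay on LNCaP cells (Homo sapiens) for antiproliferative activity, read by CCK-8 assay, with a stated time of 6 days (on this read-out lower numbers stand for stronger inhibition and higher numbers for weaker inhibition), gives 1810 nM, the top of the two numbers so far, though compound 2 `C[C@@H](Cn1ccc(-c2cc(F)c(C#N)c(Cl)c2)n1)NC(=O)Nc1cc(C(C)(C)C)[nH]n1` gives 1630 nM, which sits within the scatter of compound 1, so neither can be ranked over the other. Compound 3 `Cc1ccnc(N[C@@H](C)Cn2ccc(-c3ccc(C#N)c(Cl)c3)n2)n1` is not yet measured. It differs from compound 1 at one place (4-methylpyrimidin-2-yl in place of (2-fluorophenyl)carbonyl on an amine nitrogen). For the measured compounds named here, no measured pair isolates this change, so its effect is unknown. Compound 3 is expected to give 1500 nM (range 500 nM to 5000 nM). The estimated step of a 1.2-fold lower number from compound 1 to compound 3 (0.08 log units; within the scatter) is expected to stay within the scatter.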

Compound 3, half-maximal inhibitory concentration: 1330 nM
Estimate against measurement, compound 3: 1.1-fold (0.05 log units) above; the range from low to high includes it.
By their numbers in this assay, from the lowest: compounds 3, 2 and 1 (each within the scatter of the next).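

Among the compounds shown here, compounds 1 and 3 give the first pair that isolates this position: on an amine nitrogen whose other neighbour is a saturated chain carbon, 4-methylpyrimidin-2-yl in place of (2-fluorophenyl)carbonyl gives a 1.4-fold lower number from compound 1 to compound 3 (0.13 log units; within the scatter) in this assay. The carbonyl and the carbon-only aromatic ring of compound 1 are therefore not required for a number at this level. Nothing available explains why the two groups read alike.

Open, as far as these compounds go, is whether a smaller acetyl group or the free amine on this nitrogen would also stay within the scatter of compound 1. From the compounds shown here alone, whether the same swap behaves alike on the core of compound 2 also remains open.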